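The compounds below may be only part of what the source reports. "The series", "measured", "known", "first", "only" and "open" are said of these compounds alone.

In a physicochemical assay for acid dissociation, compound 1 `CCOC(=O)c1c(O)nnn1Cc1ccccc1` gives 5.38 and compound 2 `CCOC(=O)c1nn(Cc2ccccc2)nc1O` gives 5.14 and these two values lie within the scatter of each other. Compound 3 `CCOC(=O)c1nn(C)nc1O` is still unmeasured. Going from compound 2 to compound 3 brings the change hydrogen in place of phenyl on a saturated chain carbon bound to an aromatic nitrogen with hydrogen in place of phenyl on a saturated chain carbon bound to an aromatic nitrogen. Among the compounds with values here, no measured pair shows this change, so only a small upward move in this assay is expected, within the scatter, an estimated a number 0.16 log units higher from compound 2 to compound 3 (within the scatter) overall. For compound 3 the estimated value is 5.3 with an expected range from 4.95 to 5.65 in this measurement.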

Compound 3, acid dissociation constant: 5.14
Compound 3: middle estimate off by 0.16 log units, on the high side, and the stated range covers the measured number.
By their numbers in this assay, from the lowest: compounds 2, 3 and 1 (each within the scatter of the next).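

Within the data shown here, the step of no change at the digits printed from compound 2 to compound 3 (within the scatter) is the first comparison of compounds differing in one place in this assay. It shows that this saturated chain carbon bound to an aromatic nitrogen can lose its phenyl, with all six of its carbons, without a change beyond the scatter. Nothing available explains this result.

From the compounds shown here alone, whether this holds for other groups stays open, since only hydrogen and phenyl are compared at this place. A carboxylic acid or an amine on that carbon could give a different number.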